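A few compounds are considered here, and "the series" means these few. Any claim that something is new, unique, unknown or untested is made for them only; others in the source may bear on it.

Values measured in a functional assay on HCT-116 cells (Homo sapiens) for antiproliferative activity, read by MTT assay, with a stated time of 24 h (on this read-out higher numbers stand for weaker inhibition and lower numbers for stronger inhibition), each of them a limit:

Compound 1 `COc1ccc(C(=O)/C=C/c2ccco2)c2c1C=CC(C)(C)O2`: > 10000 nM
Compound 2 `COc1ccc(C(=O)/C=C/c2ccc(Cl)cc2)c2c1C=CC(C)(C)O2`: > 10000 nM
Compound 3 `COc1ccc(C(=O)/C=C/c2cccc(Cl)c2)c2c1C=CC(C)(C)O2`: > 10000 nM

Compound 3 has no number in this assay, only the limit > 10000 nM. The whole set sits at one ceiling, (the limit of > 10000 nM in this assay, at which 3 of the 3 values shown sit). Compound 4 `COc1ccc(C(=O)/C=C/c2cc(Cl)ccc2O)c2c1C=CC(C)(C)O2` differs from compound 3 by hydroxy in place of hydrogen on an aromatic carbon, turning 3-chlorophenyl to 5-chloro-2-hydroxyphenyl. The closest measured changes are a step that the two limits leave unreadable from compound 1 to compound 3 and a step that the two limits leave unreadable from compound 2 to compound 3. Neither has a readable size, and neither adds a hydroxy, so no step beyond the scatter is expected, although any real change could only be seen toward stronger inhibition. The expected step is a number no higher from compound 3 to compound 4 (the limit leaves the size open). The estimate for compound 4 is 10000 nM, with an expected range from 3000 nM to 30000 nM.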

Compound 4, half-maximal inhibitory concentration: 5240 nM
Compound 4: the middle estimate sits 1.9-fold (0.28 log units) above what was measured, and the stated range covers the measured number.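

For the compounds shown here, compound 4 is the first to give a number in this assay, 5240 nM, and it does so with hydroxy in place of hydrogen on an aromatic carbon, ortho to a large group and para to a chloro group. This gives an at least 1.9-fold lower number from compound 3 to compound 4 (0.28 log units; that floor lies within the scatter), alongside an at least 1.9-fold lower number from compound 2 to compound 4 (0.28 log units; that floor lies within the scatter) and an at least 1.9-fold lower number from compound 1 to compound 4 (0.28 log units; that floor lies within the scatter). The true size of these steps stays open, and those among the earlier compounds cannot be read, for all three earlier values are limits: the limit of > 10000 nM in this assay, at which 3 of the 4 values shown sit.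

On these data alone, whether an amine at this place would do the same remains open. So does whether the hydroxy gives a measurable number without the chloro group.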